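The source may hold more compounds than are shown below. What is called first, only, known or untested is meant among the compounds shown, and "the series" means these compounds.

For the measured compounds named here, compound 1 `COC(=O)C1=C(C)N=C(C)/C(=C(\O)OC)C1c1cccc(OC)c1` gives 191 nM in a functional assay (muscle tissue) with Cavia porcellus as the target (on this read-out lower numbers stand for an effect already at smaller amounts and higher numbers for an effect only at larger amounts of compound), the second highest of the three numbers measured so far. Compound 2 `COC(=O)C1=C(C)N=C(C)/C(=C(\O)OC)C1c1ccc(Cl)cc1` gives 8130 nM, a step of a 43-fold higher number from compound 1 to compound 2 (1.63 log units; beyond the scatter). Compound 3 `COC(=O)C1=C(C)N=C(C)/C(=C(\O)OC)C1c1ccccc1Cl` gives 2.19 nM, a step of an 87-fold lower number from compound 1 to compound 3 (1.94 log units; beyond the scatter); between those two compounds lies a 3700-fold lower number from compound 2 to compound 3 (3.57 log units; beyond the scatter). Compound 4 `COC(=O)C1=C(C)N=C(C)/C(=C(\O)OC)C1c1cccc(N(C)C)c1` keeps the core of compound 1 and alters a single group: dimethylamino in place of methoxy on an aromatic carbon. Going by the values given here, none of the measured steps bears directly on this change, since each of them exchanged the whole aromatic substituent rather than one group on it. Without such a guide, the step is expected to stay within the scatter, a 1.3-fold higher number from compound 1 to compound 4 (0.12 log units; within the scatter). Compound 4 is estimated at 250 nM, with a range from 60 nM to 1000 nM.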

Compound 4, half-maximal effective concentration: 891 nM
Compound 4: the middle estimate sits 3.6-fold (0.55 log units) below what was measured, and the stated range covers the measured number.
By their numbers in this assay, from the lowest: compound 3; then compound 1; then compound 4; then compound 2.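

In this assay, the exchange of one group on the aromatic ring, rather than the whole aromatic substituent, gives a 4.7-fold higher number from compound 1 to compound 4 (0.67 log units; beyond the scatter) and so moves the number beyond the scatter. Even this small change at a carbon meta to a large group therefore registers, and methoxy and dimethylamino are not interchangeable here. No measurement shown gives a reason for this step. Open, from the compounds shown here alone, is how a hydroxyl, a plain amino group or ethoxy on this same carbon would compare with methoxy. Also open, going by these compounds, is how dimethylamino would fare on the other carbons of the ring.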